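Swapping Methyl for Chloro on a Shared Core

A few compounds are considered here, and "the series" means these few. Any claim that something is new, unique, unknown or untested is made for them only; others in the source may bear on it.

Compound 1 `Cc1ccc2[nH]c3c(c2c1)CC[C@]1(C3=O)[C@@H](c2ccccc2)[C@@H](c2ccccc2)N[C@@]12C(=O)Nc1ccccc12` gives 19000 nM in a functional assay on MCF7 cells (Homo sapiens) for antiproliferative activity, read by MTT assay, with a stated time of 48 h; on this read-out higher numbers stand for weaker inhibition and lower numbers for stronger inhibition. Compound 2 `O=C1Nc2ccccc2[C@]12N[C@H](c1ccccc1)[C@H](c1ccccc1)[C@@]21CCc2c([nH]c3ccc(Cl)cc23)C1=O` gives 18000 nM. Compound 3 `Cc1ccc2[nH]c3c(c2c1)CC[C@]1(C3=O)[C@@H](c2cccs2)[C@@H](c2ccccc2)N[C@@]12C(=O)Nc1ccccc12` gives 14000 nM.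

All three numbers sit close together; compound 3 shows the smallest, but its gaps to compound 1 and compound 2 fall within the scatter of repeat measurements, so no ranking follows. Compound 4 `O=C1Nc2ccccc2[C@]12N[C@H](c1ccccc1)[C@H](c1cccs1)[C@@]21CCc2c([nH]c3ccc(Cl)cc23)C1=O` carries the change (chloro in place of methyl on an aromatic carbon). The same swap has been seen once already, a 1.1-fold lower number from compound 1 to compound 2 (0.02 log units; within the scatter), a step too small to count. The step from compound 3 to compound 4 is therefore expected to be similar, a 1.1-fold lower number from compound 3 to compound 4 (0.03 log units; within the scatter), with no change beyond the scatter. Compound 4 is estimated at 13000 nM, ranging from 7000 nM to 26000 nM.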

Compound 4, half-maximal inhibitory concentration: 13000 nM
Compound 4: the middle estimate sits on the measured number at the digits printed; measured number inside the range.
By their numbers in this assay, from the lowest: compounds 4, 3, 2 and 1 (each within the scatter of the next).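

In this assay, chloro in place of methyl on this aromatic carbon now reads on a second core, giving a 1.1-fold lower number from compound 3 to compound 4 (0.03 log units; within the scatter), and the two readings agree: the same change on two cores in this assay, a 1.1-fold lower number (0.02 log units; within the scatter) from compound 1 to compound 2 and a 1.1-fold lower number (0.03 log units; within the scatter) from compound 3 to compound 4, 1.0-fold (0.01 log units) apart, within the scatter of two such steps

Thiophen-2-yl in place of phenyl on a saturated ring carbon also gains a second reading, giving a 1.4-fold lower number from compound 2 to compound 4 (0.14 log units; within the scatter), and again the two agree: the same change on two cores in this assay, a 1.4-fold lower number (0.13 log units; within the scatter) from compound 1 to compound 3 and a 1.4-fold lower number (0.14 log units; within the scatter) from compound 2 to compound 4, 1.0-fold (0.01 log units) apart, within the scatter of two such steps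

Each change therefore looks the same whichever form the other place takes, and even with both made together the number stays within the scatter.

Only methyl and chloro are shown on this aromatic carbon. On these data alone, whether a methoxy, an amine or a carboxylic acid there could move the number beyond the scatter remains open.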